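Swapping acetyl for methyl on a lipophilic amide

The source may hold more compounds than are shown below. What is called first, only, known or untested is meant among the compounds shown, and "the series" means these compounds.

Measured in a physicochemical assay for solubility, read by nephelometry, measured as kinetic solubility, at pH 6.5; a lower number here means a less soluble compound, a higher number a more soluble compound:
- compound 1 `NCc1csc(NC(=O)c2ccon2)n1`: 50 ug/mL
- compound 2 `CC(=O)NCc1csc(NC(=O)c2cc(C(C)(C)C)nn2Cc2ccccc2)n1`: 12.5 ug/mL
- compound 3 `NCc1csc(NC(=O)c2ccn[nH]2)n1`: > 100 ug/mL, a limit of the assay

Compound 2 gives the lower of the two actual numbers, 12.5 ug/mL, and the gap to compound 1, at 50 ug/mL, lies beyond the scatter. Compound 4 `CNCc1csc(NC(=O)c2cc(C(C)(C)C)nn2Cc2ccccc2)n1` keeps the core of compound 2 and changes one group, with methyl in place of acetyl on an amine nitrogen. For the measured compounds named here, no measured step makes this change. Going by the values given here, the only step available, an at least 2.0-fold higher number from compound 1 to compound 3 (0.30 log units; that floor lies within the scatter), concerns a different group and reaches no further than the scatter, so it offers no size to carry over. Compound 1, which has no acetyl, gives 50 ug/mL, but it differs from compound 2 in more than one place, so it supports only a cautious expectation of a rise. A moderate upward step is therefore expected: a 2.8-fold higher number from compound 2 to compound 4 (0.45 log units; beyond the scatter). For compound 4 the estimate is 35 ug/mL, with an expected range of 12 ug/mL to 100 ug/mL.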

Compound 4, solubility: 12.5 ug/mL
For compound 4 the middle estimate is 2.8-fold (0.45 log units) above the measured one, within the range that was stated.
By their numbers in this assay, from the lowest: compounds 2 and 4 (each within the scatter of the next); then compound 1. At a limit, above all of these: compound 3.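

In this assay, methyl in place of acetyl on an amine nitrogen gives no change at the digits printed from compound 2 to compound 4 (within the scatter). The earlier compounds shown here held no step at this position, and this one shows that, on the core of compound 2, acetamidomethyl and (methylamino)methyl cannot be told apart by this read-out. Neither compound 2 nor compound 4 sits at a limit, and the one value that does belongs to compound 3: the limit of > 100 ug/mL in this assay, at which 1 of the 4 values shown sits.

On these data alone, it remains open whether the same change would read alike on the core of compound 1, which carries a different amide part. Also open, as far as these compounds go, is how the unsubstituted amine, a carboxylic acid or a longer chain in this place would read in this assay on the core of compound 2.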